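This account rests on a few compounds, and the source may have more. Where it says the series, first, only, none or still open, it means among the compounds named here.

Of the compounds shown here, three of one series have been measured in a functional assay on B16 cells (Mus musculus) for cytotoxicity, read by MTT assay; on this read-out higher numbers stand for weaker inhibition and lower numbers for stronger inhibition. Compound 1, `CC(=O)O[C@@H]1OC(=O)[C@@](C(C)=O)(C2SCCCS2)[C@@H]1C`, gives only a limit in this assay, > 50000 nM. Compound 2, `CC(=O)[C@@]1(C)C(=O)O[C@@H](OC(=O)C(C)(C)C)[C@H]1C`, gives 2000 nM in this assay. Compound 3, `CC(=O)[C@@]1(C)C(=O)O[C@@H](OC(=O)c2ccccc2)[C@H]1C`, gives 1000 nM in this assay; of the two numbers reported this is the smaller, but the step of a 2.0-fold lower number from compound 2 to compound 3 (0.30 log units; within the scatter) lies within the scatter, so the two compounds cannot be told apart on this read-out.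

Compound 4, `CC(=O)[C@]1(C)C(=O)O[C@@H](OC(=O)c2ccccc2)[C@H]1C`, has not yet been measured. It differs from compound 3 in this way: the two compounds have the same atoms and bonds and differ only in configuration as drawn: 1 of 3 stereo elements differ; a stereocentre at a saturated ring carbon is drawn S in compound 3 and R in compound 4. For the measured compounds named here, no measured step bears on a change of configuration. Going by the values given here, the only measured step, a 2.0-fold lower number from compound 2 to compound 3 (0.30 log units; within the scatter), concerns an exchange of groups on a carbonyl carbon and is itself within the scatter, while compound 1 contributes only a limit. The numbers therefore give no ground for expecting a shift in either direction beyond the scatter, and equally no ground for ruling one out, so the expectation carries a wide range.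

Compound 4 is accordingly expected to give 1200 nM in this assay, with an expected range from 300 nM to 8000 nM. The expected step is a 1.2-fold higher number from compound 3 to compound 4 (0.08 log units; within the scatter), that is, no change beyond the scatter.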

Compound 4, half-maximal inhibitory concentration: 5000 nM
Estimate against measurement, compound 4: 4.2-fold (0.62 log units) below; the range from low to high includes it.
By their numbers in this assay, from the lowest: compounds 3 and 2 (each within the scatter of the next); then compound 4. At a limit, above all of these: compound 1.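

In this assay the series now holds a 5.0-fold higher number from compound 3 to compound 4 (0.70 log units; beyond the scatter), and this is the only listed step that lies beyond the scatter. Configuration at this saturated ring carbon therefore counts on this read-out, with the form drawn S giving the lower number, and the shift can be assigned to that single stereocentre, with nothing leaving and nothing entering, because of this: the fact that compounds 3 and 4 differ only in the configuration as drawn The earlier step, a 2.0-fold lower number from compound 2 to compound 3 (0.30 log units; within the scatter), with phenyl in place of tert-butyl on a carbonyl carbon, did not separate its two compounds, so this modest change in configuration is the first change shown to move the number in this assay.

Going by these compounds, whether the same inversion would act alike with tert-butyl in place of phenyl, at the other two stereo elements, or with an amine or a carboxylic acid carried on the phenyl group, stays open. Compound 1 gives only a limit, > 50000 nM, and it differs from the others in more than one place, so it offers no comparison on this stereocentre.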